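Methoxy for fluoro on the fused ring of the core

The source may report more compounds than this note shows. Statements on the series, on what has been measured and on what is new or still open speak of the compounds shown alone.

Measured in a functional assay on A549 cells (Homo sapiens) for cytotoxicity, read by MTT assay, with a stated time of 48 h; on this read-out lower numbers stand for stronger inhibition and higher numbers for weaker inhibition:
compound 1 `Cc1ccc(Cn2c(/C=C3\SC(=S)N(CC(=O)O)C3=O)nc3ccc(F)cc32)cc1` gives 9640 nM.
compound 2 `COc1ccc2nc(/C=C3\SC(=S)N(CC(=O)O)C3=O)n(Cc3ccc(C)cc3)c2c1` gives 23600 nM.
compound 3 `O=C(O)CN1C(=O)/C(=C/c2nc3cc(F)ccc3n2Cc2ccccc2F)SC1=S` gives 32700 nM.

Compound 1 and compound 2 differ in one place: methoxy in place of fluoro on an aromatic carbon. That change gives a 2.4-fold higher number from compound 1 to compound 2 (0.39 log units; beyond the scatter) in this assay. Compound 3 carries a different core; the difference between the core of compound 3 and that of compound 1 is not broken down here. Compound 3 shows the highest of the three numbers; its number lies beyond the scatter against compound 1, while against compound 2 the two numbers lie within the scatter of each other, so no order is drawn between them.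

Compound 4 `COc1ccc2c(c1)nc(/C=C1\SC(=S)N(CC(=O)O)C1=O)n2Cc1ccccc1F` is not yet measured. It differs from compound 3 by methoxy in place of fluoro on an aromatic carbon. Going by the values given here, this is the same change as the one between compound 1 and compound 2, made on the core of compound 3; the two places read alike word for word. Among the compounds with values here, the only guide is the single measured step, so the step from compound 3 to compound 4 is expected to be of a similar size, a 2.1-fold higher number from compound 3 to compound 4 (0.33 log units; beyond the scatter), resting on a 2.4-fold higher number from compound 1 to compound 2 (0.39 log units; beyond the scatter). Within the data shown here, with only one earlier example, the range is kept wide. For compound 4 in this assay the estimate is 70000 nM, with an expected span from 25000 nM to 200000 nM.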

Compound 4, half-maximal inhibitory concentration: 18400 nM
For compound 4 the middle estimate is 3.8-fold (0.58 log units) above the measured one; measured number outside the range, below it.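

On the core of compound 3, methoxy in place of fluoro on an aromatic carbon gives a 1.8-fold lower number from compound 3 to compound 4 (0.25 log units; within the scatter) in this assay, so no order is drawn between compound 3 and compound 4. The same change therefore does not carry its size from the core of compound 1 to the core of compound 3, and a step read on one of these cores is a poor guide to the other: the same change on two cores in this assay, a 2.4-fold higher number (0.39 log units; beyond the scatter) from compound 1 to compound 2 and a 1.8-fold lower number (0.25 log units; within the scatter) from compound 3 to compound 4, 4.4-fold (0.64 log units) apart, beyond the scatter of two such steps

This rests on a single pair for each core, so it does not show which difference between the two cores goes with the gap, nor how the change would read on any further core.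

All four compounds shown keep the carboxylic acid and carry only fluoro or methoxy on the fused ring of the core, so it remains open how an amine, a nitrile or a hydroxyl at that aromatic carbon would read in this assay. Also open, from the compounds shown here alone, is whether an amide in place of the carboxylic acid, or a longer chain bearing that acid, would leave the numbers in this range.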